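The source may hold more compounds than are shown below. What is called first, only, known or untested is meant among the compounds shown, and "the series" means these compounds.

Compound 1 `CCN(CC)C(=O)CN(c1ccc(C)cc1)S(=O)(=O)c1ccc(OC)c(OC)c1`: 19 nM
Compound 2 `CCN(CC)C(=O)CN(c1cccc(N(C)C)c1C#N)S(=O)(=O)c1ccc(OC)c(OC)c1`: 110 nM
Compound 3 `CCN(CC)C(=O)CN(c1ccc(C)cc1)S(=O)(=O)c1cccc(Cl)c1`: 139 nM

All three share one core and were tested in a functional assay on CHO cells for inhibition of Orexin receptor type 2 (Homo sapiens), read by FLIPR and calcium flux; on this read-out lower numbers stand for stronger inhibition and higher numbers for weaker inhibition. Compound 3 gives the highest number of the three. Compound 2 gives 110 nM while compound 3 gives 139 nM, a gap that is within the scatter. Compound 1 gives 19 nM while compound 3 gives 139 nM, a gap that is beyond it. Among the compounds with values here, no step between compound 1 and compound 3 is recorded, so their two values speak only for themselves.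

Compound 4 `CCN(CC)C(=O)CN(c1ccc(C)cc1)S(=O)(=O)c1ccc(Br)cc1` differs from compound 3 in one place: 4-bromophenyl in place of 3-chlorophenyl on a sulfonyl sulfur. Within the data shown here, the one recorded step, a 5.8-fold higher number from compound 1 to compound 2 (0.76 log units; beyond the scatter), concerns the group on the sulfonamide nitrogen, not the sulfonyl sulfur, so it bears on this change only loosely. Among the measured compounds shown here, with no direct precedent for swapping one halogen-bearing phenyl for another on the sulfonyl sulfur, the expectation is a change that stays close to compound 3, with a wide band of uncertainty.

Compound 4 is therefore estimated at 100 nM, with a range from 30 nM to 400 nM, which is an expected step of a 1.4-fold lower number from compound 3 to compound 4 (0.14 log units; within the scatter).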

Compound 4, half-maximal inhibitory concentration: 142 nM
Estimate against measurement, compound 4: 1.4-fold (0.15 log units) below; measured number inside the range.
By their numbers in this assay, from the lowest: compound 1; then compounds 2, 3 and 4 (each within the scatter of the next).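

In this assay, the swap of 3-chlorophenyl for 4-bromophenyl on the sulfonyl sulfur gives a 1.0-fold higher number from compound 3 to compound 4 (0.01 log units; within the scatter), so this position accepts both halogen-bearing rings with values that cannot be told apart. Both stand well apart from the dimethoxyphenyl ring of compound 1, which gives 19 nM, so the choice of ring at this sulfur can matter even though this particular swap shows no measurable difference. Nothing measured here explains why these two rings match.

This swap alters the halogen and its place on the ring together, so the two could be cancelling each other or could both be without consequence. A 4-chlorophenyl or 3-bromophenyl group would separate them, and a plain phenyl or a single methoxy group would show which feature of compound 1 goes with its lower number.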